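Aryl exchange on the double-bonded chain carbon, compound 3 to 4

The source may report more compounds than this note shows. Statements on the series, on what has been measured and on what is new or still open speak of the compounds shown alone.

Of the compounds shown here, three with a shared core have been measured in a functional assay on HT-29 cells (Homo sapiens) for inhibition, read by MTT assay, with a stated time of 48 h; a lower number here means a stronger inhibitor, a higher number a weaker inhibitor. Compound 1 `COc1cc(/C=C/c2ccc(NC(=O)/C=C/c3cc(OC)c(O)c(OC)c3)cc2)cc(OC)c1` gives 3080 nM, compound 2 `COc1cc(/C=C/c2ccc(NC(=O)/C=C/c3ccc(C#N)cc3)cc2)cc(OC)c1` gives 3320 nM, and compound 3 `COc1cc(/C=C/c2ccc(NC(=O)/C=C/c3ccccc3F)cc2)cc(OC)c1` gives 2820 nM. Compound 3 has the lowest of the three numbers, yet the gaps to the others are within the scatter: a 1.1-fold lower number from compound 1 to compound 3 (0.04 log units; within the scatter) and a 1.2-fold lower number from compound 2 to compound 3 (0.07 log units; within the scatter). Compound 4 `COc1cc(/C=C/c2ccc(NC(=O)/C=C/c3ccc(O)c(O)c3)cc2)cc(OC)c1` is not yet measured; it differs from compound 3 by 3,4-dihydroxyphenyl in place of 2-fluorophenyl on a double-bonded chain carbon bound to a double-bonded chain carbon.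

All three measured steps exchange the aryl group at this same place, and none moves the number beyond the scatter: a 1.1-fold higher number from compound 1 to compound 2 (0.03 log units; within the scatter), and the two steps to compound 3 given above. Compound 1 carries a hydroxy-bearing ring and is the nearest measured neighbour to the entering 3,4-dihydroxyphenyl; its step to compound 3 is flat. Nothing in these data marks this place as one where an aryl exchange shifts the read-out. In this assay the expected step is therefore a 1.1-fold higher number from compound 3 to compound 4 (0.03 log units; within the scatter), nothing beyond the scatter. Compound 4 is estimated at 3000 nM, with a range from 1400 nM to 6500 nM.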

Compound 4, half-maximal inhibitory concentration: 1560 nM
Compound 4: the middle estimate sits 1.9-fold (0.28 log units) above what was measured, and the stated range covers the measured number.
By their numbers in this assay, from the lowest: compounds 4, 3, 1 and 2 (each within the scatter of the next, the first and the last beyond it).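

In this assay, this place on a double-bonded chain carbon bound to a double-bonded chain carbon gave only steps within the scatter across the earlier aryl exchanges, and it now gives its first step beyond the scatter, a 2.1-fold lower number from compound 2 to compound 4 (0.33 log units; beyond the scatter), a modest one with 3,4-dihydroxyphenyl entering in place of 4-cyanophenyl. The other two steps into compound 4, a 1.8-fold lower number from compound 3 to compound 4 (0.26 log units; within the scatter) and a 2.0-fold lower number from compound 1 to compound 4 (0.30 log units; within the scatter), remain within the scatter, so the aryl group at this place is shown to matter for a single pair only, and compound 4 is not separated from the whole series. No measurement bears on what lies behind this step.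

The compounds shown leave open whether the step needs both hydroxy groups of the entering ring, a question that a 4-hydroxyphenyl or a 3,4-dimethoxyphenyl at this place could address. They also leave open whether a 4-aminophenyl or a 4-carboxyphenyl at this place would match compound 4 or stay with compound 2 in this assay.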